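Working notes: from compound 2 to compound 3

A few compounds are considered here, and "the series" means these few. Any claim that something is new, unique, unknown or untested is made for them only; others in the source may bear on it.

- compound 1 `CN(C)C(=O)c1cc2cnc(Nc3ccc(NC(=O)C4(C(=O)Nc5ccc(Cl)cc5)CC4)cc3)nc2n1C1CCCC1`: 8.1%
- compound 2 `CN(C)C(=O)c1cc2cnc(Nc3ccc(NC(=O)C4(C(=O)Nc5cccc(Cl)c5)CC4)cc3)nc2n1C1CCCC1`: 15.5%
- compound 3 `CN(C)C(=O)c1cc2cnc(Nc3ccc(NC(=O)C4(C(=O)Nc5ccc(O)cc5)CC4)cc3)nc2n1C1CCCC1`: not yet measured

In a functional assay on OVCAR-5 cells (Homo sapiens) for inhibition, read by CCK-8 assay, with a stated time of 72 h, tested at 1 uM (on this read-out lower numbers stand for less inhibition of growth and higher numbers for more inhibition of growth at the one concentration tested), compound 2 gives 15.5%, within the scatter of compound 1 at 8.1%. The next change is 4-hydroxyphenyl in place of 3-chlorophenyl on an amide-type nitrogen. Going by the values given here, only one measured step bears on it: a number 7.4 percentage points higher from compound 1 to compound 2 (within the scatter). Among the compounds with values here, that step exchanges one chlorophenyl group for another at the same place, so no measured compound shows what a 4-hydroxyphenyl group does here. Going by these compounds, with so little evidence, no shift beyond the scatter is expected in this assay, and the direction stays open. The expected step is a number 3.5 percentage points lower from compound 2 to compound 3 (within the scatter). Compound 3 is estimated at 12%, with an expected range of 2% to 26%.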

Compound 3, percent growth inhibition at one concentration: 80.7%
Beside the measured number, compound 3's estimate is 68.7 percentage points below it; the whole stated range lies below it.
By their numbers in this assay, from the lowest: compounds 1 and 2 (each within the scatter of the next); then compound 3.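

In this assay, this position on the amide-type nitrogen proves highly sensitive to the aryl substituent: 4-hydroxyphenyl gives a number 65.2 percentage points higher from compound 2 to compound 3 (beyond the scatter) in place of 3-chlorophenyl, and hydroxy in place of chloro gives a number 72.6 percentage points higher from compound 1 to compound 3 (beyond the scatter) on the same aromatic carbon. The exchange between chlorophenyl groups gave no sign of a change this large. No data on hand account for the gain.

Going by these compounds, whether the gain is specific to the hydroxy group remains open, as an amine or a methoxy group on the same aromatic carbon would test this. On these data alone, whether 3-hydroxyphenyl matches 4-hydroxyphenyl also remains open.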